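The compounds below may be only part of what the source reports. "The series", "measured", "known", "first", "only" and "open" are said of these compounds alone.

Measured so far:
compound 1 `COc1ccc(C2Oc3ccccc3N(CCCCCN3C(C)CCCC3C)C2=O)cc1OC` — 0%
compound 2 `CC1CCCC(C)N1CCCCCN1C(=O)C(c2cccc(C(=N)NO)c2)Oc2ccccc21` — 21%
compound 3 `CC1CCCC(C)N1CCCCCN1C(=O)C(c2ccc(Cl)cc2)Oc2ccccc21` — 46%

In an assay on isolated protein for inhibition of serine protease 1 (Homo sapiens), tested at 100 uM (a higher number here means more inhibition at the concentration tested (going by the name of the read-out), a lower number less inhibition), compound 3 stands highest of the three, with compound 2 nearest and compound 1 furthest; both gaps are beyond the scatter. The steps are a number 46 percentage points higher from compound 1 to compound 3 (beyond the scatter), a number 25 percentage points higher from compound 2 to compound 3 (beyond the scatter) and a number 21 percentage points higher from compound 1 to compound 2 (beyond the scatter), so the group on the saturated ring carbon has moved the read-out in every case.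

Compound 4 `CC1CCCC(C)N1CCCCCN1C(=O)C(c2ccc(C(=N)NO)cc2)Oc2ccccc21` differs from compound 3 by a group of 4 heavy atoms (1 carbon, 2 nitrogen, 1 oxygen; no ring) in place of one chlorine atom, on an aromatic carbon. The step that bears most directly on it is a number 25 percentage points higher from compound 2 to compound 3 (beyond the scatter), since compound 2 also carries this entering group: there, removing it in favour of chloro raised the read-out by a modest amount. The reverse change in compound 4 is therefore expected to lower this assay by a modest amount, though the ring position is not the same, so the size is uncertain.

Estimated for compound 4: 28%, range 5% to 60%, an expected step of a number 18 percentage points lower from compound 3 to compound 4 (beyond the scatter).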

Compound 4, a percentage reported as inhibition, at one concentration (the size of the read-out at that concentration, not a potency): 8%
Estimate against measurement, compound 4: 20 percentage points above, within the range that was stated.
By their numbers in this assay, from the lowest: compounds 1 and 4 (each within the scatter of the next); then compound 2; then compound 3.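

Among these compounds, compound 3 and compound 4 give the first comparison at a single aromatic carbon, para to a large group, where the group of 4 heavy atoms replaces chloro: a number 38 percentage points lower from compound 3 to compound 4 (beyond the scatter) in this assay. The same entering group also proves sensitive to where it sits on the ring, with a number 13 percentage points lower from compound 2 to compound 4 (beyond the scatter), so its placement in compound 4 reads lower than its placement in compound 2. Against the 3,4-dimethoxyphenyl compound, the step is a number 8 percentage points higher from compound 1 to compound 4 (within the scatter), so this change gives no separation from that group.

Nothing measured on these compounds accounts for these steps. From the compounds shown here alone, whether bromo, methyl or a carboxylic acid on the same aromatic carbon would stay near compound 3 or fall towards compound 4 remains open.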